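The source may hold more compounds than are shown below. What is called first, only, known or untested is meant among the compounds shown, and "the series" means these compounds.

Compound 1 `O=c1c([C@@H]2C[C@H](c3ccccc3)ON2c2ccccc2)coc2ccc(F)cc12` gives 54700 nM in a functional assay on THP-1 cells (Homo sapiens) for inhibition, read by sulforhodamine B assay, with a stated time of 48 h; on this read-out higher numbers stand for weaker inhibition and lower numbers for stronger inhibition.
Compound 2 `COC(=O)[C@@]1(C)C[C@@H](c2coc3ccc(F)cc3c2=O)N(c2ccccc2)O1` gives 47000 nM in this assay.
Compound 3 `Cc1ccc2occ([C@@H]3C[C@H](c4ccccc4)ON3c3ccccc3)c(=O)c2c1` gives > 60000 nM in this assay, which is a limit of the assay rather than a number.

All three are weak inhibitors of these cells. The difference between the cores of compound 1 and compound 2 is not broken down here; their two values lie within the usual scatter of each other. Compound 1 and compound 3 differ by one change, (methyl in place of fluoro on an aromatic carbon), and the measured step is an at least 1.0-fold higher number from compound 1 to compound 3 (0.04 log units; that floor lies within the scatter). That step is only a floor because compound 3 sits at the limit of > 60000 nM in this assay, at which 1 of the 3 values shown sits.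

Compound 4 `COC(=O)[C@@]1(C)C[C@@H](c2coc3ccc(C)cc3c2=O)N(c2ccccc2)O1` has not yet been measured. It differs from compound 2 by methyl in place of fluoro on an aromatic carbon, the same change, at the same place, as from compound 1 to compound 3. The step expected from compound 2 to compound 4 is a 1.4-fold higher number from compound 2 to compound 4 (0.14 log units; within the scatter), resting on the earlier step from compound 1 to compound 3 of an at least 1.0-fold higher number from compound 1 to compound 3 (0.04 log units; that floor lies within the scatter), which reached the limit. Compound 4 is therefore estimated at about 65000 nM, likely between 35000 nM and 120000 nM, with a real chance that only a limit is reported.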

Compound 4, half-maximal inhibitory concentration: 7300 nM
Estimate against measurement, compound 4: 8.9-fold (0.95 log units) above; the measured number lies below the stated range.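

Methyl in place of fluoro on an aromatic carbon gives a 6.4-fold lower number from compound 2 to compound 4 (0.81 log units; beyond the scatter), and this does not match the same change on the other core: the same change on two cores in this assay, an at least 1.0-fold higher number (0.04 log units; that floor lies within the scatter) from compound 1 to compound 3 and a 6.4-fold lower number (0.81 log units; beyond the scatter) from compound 2 to compound 4, at least 7.0-fold (0.84 log units) apart, beyond the scatter of two such steps

The earlier step is only a floor, as compound 3 stands at a limit: the limit of > 60000 nM in this assay, at which 1 of the 4 values shown sits.

So the outcome of this change on one core did not predict its outcome on the other, but these two pairs show neither why the cores part ways nor how large the true gap is.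

The compounds shown leave open whether a chloro group, a methoxy group or an amine at the same place would behave like the methyl of compound 4. They also leave open which part of the core of compound 2, such as its methyl ester, goes with the stronger inhibition.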